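This account rests on a few compounds, and the source may have more. Where it says the series, first, only, none or still open, it means among the compounds named here.

Measured in a functional assay on DU-145 cells (Homo sapiens) for cytotoxicity, read by MTT assay, with a stated time of 24 h; a lower number here means a stronger inhibitor, a higher number a weaker inhibitor:

- compound 1 `O=C1/C(=C/c2ccccc2F)CN(Cc2cn(Cc3ccccc3F)nn2)C/C1=C\c1ccccc1F`: 10600 nM
- compound 2 `O=C1/C(=C/c2ccccc2F)CN(C(=S)SCc2cn(Cc3ccccc3Cl)nn2)C/C1=C\c1ccccc1F`: 46300 nM
- compound 3 `O=C1/C(=C/c2ccccc2F)CN(C(=S)SCc2cn(Cc3ccccc3F)nn2)C/C1=C\c1ccccc1F`: > 80000 nM, a limit of the assay and not a number

Compound 3 has no number of its own and stands at the limit of > 80000 nM in this assay, at which 1 of the 3 values shown sits.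

Compound 4 `O=C1/C(=C/c2ccccc2F)CN(C(=S)SCc2cn(Cc3ccc(F)cc3)nn2)C/C1=C\c1ccccc1F` differs from it by 2-fluorobenzyl to 4-fluorobenzyl, that is, 4-fluorophenyl in place of 2-fluorophenyl on a saturated chain carbon bound to an aromatic nitrogen.

Among the compounds with values here, one measured step touches this group: an at least 1.7-fold higher number from compound 2 to compound 3 (0.23 log units; that floor lies within the scatter), with fluoro in place of chloro. That step is a floor and lies within the scatter, and it does not shift the fluorine on the ring, so no measurement speaks directly to the change at hand. The estimate leans on compound 2, with 46300 nM, as the closest measured neighbour with a number.

In this assay the expected step is an at least 1.3-fold lower number from compound 3 to compound 4 (0.12 log units; that floor lies within the scatter), with nothing beyond the scatter anticipated, and a second limit remains quite possible.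

For compound 4 the estimated value is 60000 nM, with an expected range from 25000 nM to 100000 nM.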

Compound 4, half-maximal inhibitory concentration: 35700 nM
For compound 4 the middle estimate is 1.7-fold (0.23 log units) above the measured one; low and high end bracket the measured number.
By their numbers in this assay, from the lowest: compound 1; then compounds 4 and 2 (each within the scatter of the next). At a limit, above all of these: compound 3.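

In this assay, within the data shown here, 2-fluorobenzyl to 4-fluorobenzyl gives an at least 2.2-fold lower number from compound 3 to compound 4 (0.35 log units; beyond the scatter), the first step at this group that clears the scatter, so the place of the fluorine on this ring counts for something that the change of halogen alone did not show. The size of that step is only a floor, as compound 3 has no number of its own, only a limit of the assay: the limit of > 80000 nM in this assay, at which 1 of the 4 values shown sits.

The other comparison reads a 1.3-fold lower number from compound 2 to compound 4 (0.11 log units; within the scatter), so 4-fluorophenyl and 2-chlorophenyl on this saturated chain carbon cannot be told apart here.

From the compounds shown here alone, whether an unsubstituted benzyl, a methoxybenzyl or a pyridylmethyl group at this place would sit with compound 4 or with compound 3 stays open. Also open, going by these compounds, is whether 4-fluorobenzyl would shift the value in the same way on the core of compound 1.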